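This account rests on a few compounds, and the source may have more. Where it says the series, first, only, none or still open, it means among the compounds named here.

In a functional assay on NCI-H1581 cells (Homo sapiens) for inhibition, read by MTT assay, with a stated time of 72 h (on this read-out lower numbers stand for stronger inhibition and higher numbers for weaker inhibition), compound 1 `CCc1nc2c(C)cc(-c3ccc(CN4CCC(O)CC4)cc3)cn2c1NC(=O)OCc1cc(Cl)cc(Cl)c1` gives 4800 nM, the only number available among these compounds. From the compounds shown here alone, compound 2 `CCc1nc2c(C)cc(-c3ccc(CN4CCN(C)CC4)cc3)cn2c1NC(=O)OCc1cc(Cl)cc(Cl)c1` has no such number: for compound 2 the record reads "nd" (no result reported), so no result was reported and its standing in this assay remains open. Compound 3 `CCc1nc2c(C)cc(-c3ccc(CN4CCC(C)CC4)cc3)cn2c1NC(=O)OCc1cc(Cl)cc(Cl)c1` has yet to be measured. The structural change is 4-methylpiperidin-1-yl in place of 4-methylpiperazin-1-yl on a saturated chain carbon bound to an aromatic carbon, with 4-methylpiperidin-1-yl in place of 4-methylpiperazin-1-yl on a saturated chain carbon bound to an aromatic carbon. Going by the values given here, no measured step in this assay shows the effect of this change, and without a value for compound 2 its size cannot be read from the data. No step beyond the scatter is expected in either direction, so the expectation rests on compound 1 at 4800 nM. Compound 3 is expected at about 3500 nM, with an estimated range of 1000 nM to 10000 nM.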

Compound 3, half-maximal inhibitory concentration: 4040 nM
Compound 3: middle estimate off by 1.2-fold (0.06 log units), on the low side; the measured number falls inside the stated range.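

Compound 3 gives the first comparison among these compounds: in this assay, methyl in place of hydroxy on a saturated ring carbon gives a 1.2-fold lower number from compound 1 to compound 3 (0.07 log units; within the scatter), so this change does not separate the two compounds. The step from compound 2 to compound 3 cannot be read, as compound 2 has no reported result, and the exchange of 4-methylpiperazin-1-yl for 4-methylpiperidin-1-yl therefore remains without a measured size. No supporting data are available to explain the result.

From the compounds shown here alone, it remains open how an amine or a carboxylic acid in place of methyl on that saturated ring carbon would read in this assay. Morpholin-4-yl in place of 4-methylpiperidin-1-yl, on a saturated chain carbon bound to an aromatic carbon, is equally open.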